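This account rests on a few compounds, and the source may have more. Where it says the series, first, only, none or still open, it means among the compounds named here.

Measured compounds:
compound 1, `COc1ncc(-c2ccc3nc(NC(=O)NCCN(C)C)sc3c2)cc1NS(=O)(=O)c1ccc(F)cc1`, 1020 nM
compound 2, `COc1ncc(-c2ccc3nc(NC(=O)NC4CC4)sc3c2)cc1NS(=O)(=O)c1ccc(F)cc1`, 520 nM
compound 3, `CCCNc1nc2ccc(-c3cnc(Cl)c(NS(=O)(=O)c4ccc(F)cc4)c3)cc2s1`, "not determined" (no result reported)

The measurements come from a functional assay on U-87MG ATCC cells for antiproliferative activity against U-87 MG (Homo sapiens), read by MTT assay, with a stated time of 72 h; on this read-out lower numbers stand for stronger inhibition and higher numbers for weaker inhibition. In this assay compound 1 gives 1020 nM and compound 2 gives 520 nM. For the measured compounds named here, the only step between two measured compounds is a 2.0-fold lower number from compound 1 to compound 2 (0.29 log units; within the scatter). Compound 3 has no number in this assay, so there is nothing to set it against the other two.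

The account follows the change from compound 3 to compound 4, `O=C(Nc1nc2ccc(-c3cnc(Cl)c(NS(=O)(=O)c4ccc(F)cc4)c3)cc2s1)NC1CC1`. The difference is cyclopropylcarbamoyl in place of propyl on a nitrogen on an aromatic ring. Going by the values given here, no measured step involves this change: the step from compound 1 to compound 2 alters the group on the amide-type nitrogen of an existing urea and does not compare a propylamino with a (cyclopropylcarbamoyl)amino. What the data do offer is compound 2, which carries the same cyclopropylcarbamoyl on the nitrogen on the aromatic ring as compound 4 and differs from it elsewhere; its value is the nearest reference. With compound 3 unmeasured, no direction or size of step can be expected.

Compound 4 is therefore estimated to lie near compound 2, at about 600 nM, with a range from 200 nM to 2000 nM.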

Compound 4, half-maximal inhibitory concentration: 1720 nM
Compound 4: the middle estimate sits 2.9-fold (0.46 log units) below what was measured; measured number inside the range.
By their numbers in this assay, from the lowest: compounds 2, 1 and 4 (each within the scatter of the next, the first and the last beyond it).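

The step that can be read does not concern the propylamino to (cyclopropylcarbamoyl)amino change: compound 3 has no number, so the step from it to compound 4 cannot be read, and the contribution of the cyclopropylcarbamoyl on that nitrogen remains unmeasured. For the compounds shown here, compound 4 instead gives the first reading of a different place, the aromatic carbon that carries methoxy in both earlier measured compounds. With the cyclopropyl urea held constant, chloro in place of methoxy gives a 3.3-fold higher number from compound 2 to compound 4 (0.52 log units; beyond the scatter) in this assay, a modest but real loss of inhibition on this read-out, which shows that this aromatic carbon is not indifferent to its substituent. Nothing measured here accounts for this loss.

Going by these compounds, only chloro and methoxy have been compared on that carbon, so it remains open how a methyl, a bromo, a nitrile or a simple hydrogen would behave there. On these data alone, it also remains open whether the same change would give a step of similar size with the 2-(dimethylamino)ethyl group of compound 1 on the urea, or with a longer chain or a morpholine-bearing chain in its place.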